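Ring swap at the amine-bearing carbon, cytotoxicity check

The source may hold more compounds than are shown below. What is called first, only, known or untested is meant among the compounds shown, and "the series" means these compounds.

Among the measured compounds shown here, compound 1 `Cc1nc(C(NC(=O)C(=O)Nc2ccc(Cl)cc2)C2CCCN2)sc1CO` and compound 2 `Cc1nc(C(NC(=O)C(=O)Nc2ccc(Cl)cc2)C2CCCNC2)sc1CCO` share a common core and differ from each other in more than one place, so no single step connects them. In an ADME assay on MT2 cells (Homo sapiens) for cytotoxicity, read by XTT assay, with a stated time of 4 days (on this read-out higher numbers stand for lower toxicity in this test and lower numbers for higher toxicity in this test), compound 1 gives 45000 nM. For compound 2 only a limit is reported in this assay, namely > 78500 nM, and this is the limit described by the limit of > 78500 nM in this assay, at which 1 of the 2 values shown sits. For the measured compounds named here, compound 2 thus stands at a limit rather than at a number, while compound 1 carries the only numerical value in the set.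

Compound 3 `Cc1nc(C(NC(=O)C(=O)Nc2ccc(Cl)cc2)C2CCCN2)sc1CCO` has not yet been measured. Relative to compound 2 it differs in one place: pyrrolidin-2-yl in place of piperidin-3-yl on a saturated chain carbon bound to an amide-type nitrogen and an aromatic carbon. Going by the values given here, the entering ring is the one found in compound 1, whose value in this assay lies below the limit. Among the compounds with values here, no measured pair differs in only this place, so the size of the step is not fixed by the data; a step no larger than the usual scatter, or a slightly lower value, seems most plausible. The step that this estimate means is an at least 1.3-fold lower number from compound 2 to compound 3 (0.11 log units; that floor lies within the scatter). Compound 3 is expected to give 60000 nM, within a range of 25000 nM to 150000 nM.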

Compound 3, half-maximal cytotoxic concentration: 42000 nM
Beside the measured number, compound 3's estimate is 1.4-fold (0.15 log units) above it; measured number inside the range.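

In this assay, the change to pyrrolidin-2-yl in place of piperidin-3-yl on a saturated chain carbon bound to an amide-type nitrogen and an aromatic carbon can now be read as a single step: an at least 1.8-fold lower number from compound 2 to compound 3 (0.27 log units; that floor lies within the scatter). Compound 2 carries a limit and not a number, so this step is only a floor: the limit of > 78500 nM in this assay, at which 1 of the 3 values shown sits. The chain on the shared core can also now be read alone, with hydroxymethyl in place of hydroxy on a saturated chain carbon bound to an aromatic carbon giving a 1.1-fold lower number from compound 1 to compound 3 (0.03 log units; within the scatter), so with pyrrolidin-2-yl present this change stays within the usual scatter.

On these data alone, the true size of the ring step remains open, and so does whether the same chain change would stay within the scatter with piperidin-3-yl in the molecule. Also open, as far as these compounds go, is how this read-out responds to a longer chain such as hydroxypropyl, or to a carboxylic acid or a primary amine in place of the hydroxy-bearing chain.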